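Formyl to Hydroxymethyl at the Limit of a Cytotoxicity Assay

The source may report more compounds than this note shows. Statements on the series, on what has been measured and on what is new or still open speak of the compounds shown alone.

In a functional assay on KB 3-1 cells (Homo sapiens) for cytotoxicity, read by MTT assay, with a stated time of 68 h (on this read-out lower numbers stand for stronger inhibition and higher numbers for weaker inhibition), compound 1 `CC1(C)O[C@@H]2CC[C@](C)(O)[C@H](CCC3C(C=O)=CCC4C(CC[C@@]4(C)O)C3(C)C)[C@@]2(C)CCC1=O` gives > 50000 nM, which is a limit of the assay and not a number. Its place on the scale therefore cannot be fixed any more closely. Compound 2 `CC1(C)C(CC[C@@H]2[C@@]3(C)CC[C@@H](O)C(C)(C)O[C@@H]3CC[C@]2(C)O)C(C=O)=CCC2C1CC[C@@]2(C)O` also gives only a limit, > 50000 nM. Compound 3 `CC1(C)C(CC[C@@H]2[C@@]3(C)CC[C@@H](O)C(C)(C)O[C@@H]3CC[C@]2(C)O)C(CO)=CCC2C1CC[C@@]2(C)O` likewise gives only a limit, > 50000 nM. These three results make up the whole of the measured picture: the limit of > 50000 nM in this assay, at which 3 of the 3 values shown sit.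

Compound 4 `CC1(C)O[C@@H]2CC[C@](C)(O)[C@H](CCC3C(CO)=CCC4C(CC[C@@]4(C)O)C3(C)C)[C@@]2(C)CCC1=O` has not yet been measured. It is compound 1 with a single change, hydroxymethyl in place of formyl on a double-bonded ring carbon of a seven-membered non-aromatic ring (hydroxymethyl in place of formyl on a double-bonded ring carbon).

Among the compounds with values here, one measured step bears directly on this change, since it makes the same exchange: a step that the two limits leave unreadable from compound 2 to compound 3. That step has no readable size, so it offers neither a magnitude nor a direction to carry over. What it does show is that the exchange left the compound at the limit in this assay. No step beyond the usual scatter is therefore expected here, and compound 4 is expected to stay at the limit as well. The expected step is a number no higher from compound 1 to compound 4 (the limit leaves the size open). For compound 4 the estimate is 50000 nM, with an expected range from 20000 nM to 100000 nM.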

Compound 4, half-maximal inhibitory concentration: > 50000 nM
Compound 4: no number, only a limit; the forecaster's own chance of this, stated with the estimate: 85%; the middle value lies on the limit itself.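

In this assay, within the data shown here, compound 1 and compound 4 both give only a limit and not a number, so the exchange of formyl for hydroxymethyl yields no step that can be read between them. The compounds shown leave open how far each lies beyond that limit and whether the exchange changes cytotoxicity at all, since every result rests at the same point: the limit of > 50000 nM in this assay, at which 4 of the 4 values shown sit.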